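A few compounds are considered here, and "the series" means these few. Any claim that something is new, unique, unknown or untested is made for them only; others in the source may bear on it.

The measured compounds:

Compound 1 `Cc1nc(-c2ccc(C(F)(F)F)cc2)sc1CNc1ccc(CCCC(=O)O)cc1` gives 44% in a functional assay on CHO cells for agonist activity at Free fatty acid receptor 1 (Homo sapiens), read by a luciferase reporter; on this read-out higher numbers stand for larger maximal responses and lower numbers for smaller maximal responses.
Compound 2 `CC(Cc1ccc(NCc2cccc(Oc3ccccc3)c2)cc1)C(=O)O` gives 70% in this assay.
Compound 3 `CNC(=O)CCc1ccc(NCc2cccc(Oc3ccccc3)c2)cc1` gives 67% in this assay.

Compound 1 stands lowest of the three in this assay; compound 3 sits closest to it, and the gap to compound 3 as well as the larger gap to compound 2 both lie beyond the scatter. The unmeasured compound 4 `Cc1nc(-c2ccc(C(F)(F)F)cc2)sc1CNc1ccc([C@H]2C[C@@H]2C(N)=O)cc1` differs from compound 1 in one place: 2-carbamoylcyclopropyl in place of 3-carboxypropyl on an aromatic carbon. The 3-carboxypropyl that leaves carries a carboxylic acid, while the 2-carbamoylcyclopropyl that enters carries a primary amide on a three-membered ring.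

For the measured compounds named here, one measured step bears on this exchange. Going from an acid to an amide on a saturated chain carbon bound to an aromatic carbon gave a number 3 percentage points lower from compound 2 to compound 3 (within the scatter), a change that stays within the scatter. The acid-to-amide part of the change to compound 4 is therefore expected to cost little. Going by the values given here, the ring that enters has no measured counterpart here, so nothing in the data tells how it behaves.

Compound 4 is estimated to give 45% in this assay, within a range of 25% to 65%, which means an expected step of a number 1 percentage points higher from compound 1 to compound 4 (within the scatter), not beyond the scatter.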

Compound 4, largest response reached (reported as percent of maximum), in percent of the reference or control that the assay uses: 80%
For compound 4 the middle estimate is 35 percentage points below the measured one; the whole stated range lies below it.
By their numbers in this assay, from the lowest: compound 1; then compounds 3, 2 and 4 (each within the scatter of the next, the first and the last beyond it).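

At this place, on an aromatic carbon para to a large group, the exchange of 3-carboxypropyl for 2-carbamoylcyclopropyl raises the maximal response in this assay by a large margin, with a number 36 percentage points higher from compound 1 to compound 4 (beyond the scatter) as the result. A carboxylic acid is therefore not required for a high maximal response on the core of compound 1, a point the earlier acid-to-amide comparison could not make, since a number 3 percentage points lower from compound 2 to compound 3 (within the scatter) on another core and with no ring entering. No measured evidence accounts for the size of this rise.

The ring and the primary amide enter together, so the compounds shown do not divide the gain between them: an open-chain 3-carbamoylpropyl group would carry the amide alone at this place, and a 2-carboxycyclopropyl group would carry the ring alone. Also open, as far as these compounds go, are how the other stereoisomers of 2-carbamoylcyclopropyl, with their different arrangements at the two defined stereocentres, would compare, and whether the same group would give a similar response on the core of compound 2.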